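This account rests on a few compounds, and the source may have more. Where it says the series, first, only, none or still open, it means among the compounds named here.

Measured compounds:
Compound 1 `CCCNNC(=O)c1ccc(CNC(=O)c2cc3ccccc3o2)cc1`; in an assay on isolated protein for inhibition of protein deacetylase HDAC6 (Homo sapiens), read by fluorescence, with a stated time of 2 h (a higher number here means a weaker inhibitor, a lower number a stronger inhibitor), compound 1 gives > 10000 nM, a limit of the assay.
Compound 2 `C=CCOc1ccc2oc(C(=O)NCc3ccc(C(=O)NNCCC)cc3)cc2c1`; in this assay compound 2 gives > 10000 nM, again a limit.
Compound 3 `CCCNNC(=O)c1ccc(CNC(=O)c2cc3cc(Cl)ccc3[nH]2)cc1`; in this assay compound 3 gives > 10000 nM, also a limit.

Compound 2 thus stands only at a limit in this assay. The step that the two limits leave unreadable from compound 1 to compound 2 cannot be read, as both of its ends are limits. Compound 4 `CCCNNC(=O)c1ccc(CNC(=O)c2cc3cc(OC)ccc3o2)cc1` differs from compound 2 by hydrogen in place of vinyl on a saturated chain carbon bound to an oxygen on an aromatic ring. For the measured compounds named here, the only measured step bearing on this change is a step that the two limits leave unreadable from compound 1 to compound 2, which gives no size; what the series shows is the limit of > 10000 nM in this assay, at which 3 of the 3 values shown sit. No movement beyond the scatter is expected for compound 4. For compound 4 the expected step is a step that the limit leaves unreadable from compound 2 to compound 4, essentially none. The estimate for compound 4 is 20000 nM, ranging from 8000 nM to 60000 nM, most likely reported again as a limit.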

Compound 4, half-maximal inhibitory concentration: > 10000 nM
Compound 4 was reported as a limit (the forecaster's own chance of this, stated with the estimate: 85%); the middle value does not contradict the limit.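

No step can be read among compound 1, compound 2 and compound 4, whose values are all limits: the limit of > 10000 nM in this assay, at which 4 of the 4 values shown sit. The compounds shown leave open how hydrogen, methoxy and allyloxy on the shared core compare in inhibition.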